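The source may report more compounds than this note shows. Statements on the series, on what has been measured and on what is new or still open speak of the compounds shown alone.

Working notes on the series. The shared core of compound 1 `O=C(N/N=C/c1ccc(Br)cc1)Nc1cccc2ccccc12` carries an aryl group on a carbon with a double bond to nitrogen, and compound 2 `O=C(N/N=C/c1ccccc1[N+](=O)[O-])Nc1cccc2ccccc12` and compound 3 `COc1ccc(OC)c(/C=N/NC(=O)Nc2cccc3ccccc23)c1` vary only this part. In a functional assay on the whole organism (strain Swiss albino) with Mus musculus as the target, with a stated time of 0.5 h (a lower number here means that less compound is needed, a higher number that more compound is needed for the effect), compound 1 gives 300 mg/kg. In this assay compound 2 gives 300 mg/kg, and compound 3 gives 300 mg/kg. Compound 1 thus stands level with compounds 2 and 3 at the digits given; nearest is compound 2 and furthest is compound 3, with no change beyond the scatter in either case.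

Compound 4 `O=C(N/N=C/c1ccccc1O)Nc1cccc2ccccc12` differs from compound 1 as follows: 2-hydroxyphenyl in place of 4-bromophenyl on a carbon with a double bond to nitrogen. The entering group counts one hydrogen-bond donor and one hydrogen-bond acceptor where the leaving group counts none. Among the measured compounds shown here, no step between measured compounds is recorded, and the three measured aryl variants all land at the same value. On that basis no step beyond the scatter is expected, and the step from compound 1 to compound 4 is estimated at no change at the digits printed from compound 1 to compound 4 (within the scatter). Compound 4 is expected to give 300 mg/kg in this assay, within 100 mg/kg to 600 mg/kg.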

Compound 4, minimum effective dose: 300 mg/kg
Beside the measured number, compound 4's estimate shows no gap at the digits printed; the range from low to high includes it.
By their numbers in this assay, from the lowest: compounds 1, 2, 3 and 4 (each within the scatter of the next).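

In this assay, 2-hydroxyphenyl in place of 4-bromophenyl on a carbon with a double bond to nitrogen gives no change at the digits printed from compound 1 to compound 4 (within the scatter), so bringing in the hydrogen-bond donor and acceptor counted on the entering group leaves the reading where it stood. Hydroxy in place of nitro on an aromatic carbon gives no change at the digits printed from compound 2 to compound 4 (within the scatter), so the same flat reading holds from a second starting point, now for a single group on the aromatic ring. No supporting data accompany these values to explain this flatness.

Open, as far as these compounds go, is whether any group at this position can produce a step beyond the scatter in this assay. An amine or a carboxylic acid on the aromatic ring, or a longer chain in place of the aryl group, would test this.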